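The source may report more compounds than this note shows. Statements on the series, on what has been measured and on what is new or still open speak of the compounds shown alone.

Measured compounds:
Compound 1, `COc1ccc(-c2[nH]c3ccc(C)cc3c2C=O)cc1`, gives 86 nM in a functional assay on MDA-MB-231 cells (Homo sapiens) for antiproliferative activity, with a stated time of 4 days; a higher number here means a weaker inhibitor, a lower number a stronger inhibitor.
Compound 2, `CCCCc1ccc2[nH]c(-c3ccc(OC)cc3)c(/C=N/NC(=O)c3ccccc3)c2c1`, gives 32 nM in this assay.
Compound 3, `CCCCc1ccc2[nH]c(-c3ccc(C(F)(F)F)cc3)c(/C=N/NC(=O)c3cccnc3)c2c1`, gives 97 nM in this assay.

Compound 2 has the lowest number of the three in this assay. Compound 1 stands nearest to it and compound 3 furthest, and both gaps lie beyond the usual scatter, so compound 2 is the strongest inhibitor of this small set.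

Compound 4, `CCCCc1ccc2[nH]c(-c3ccc(OC)cc3)c(/C=N/NC(=O)c3ccccn3)c2c1`, has not yet been measured. It differs from compound 2 in a single place: pyridin-2-yl in place of phenyl on a carbonyl carbon. The rest of the molecule, including the butyl chain and the methoxy group, is unchanged.

Among the compounds with values here, no pair of measured compounds isolates this change. Compound 3 carries a pyridin-3-yl on the same carbonyl carbon, but it also carries a trifluoromethyl group in place of the methoxy group, and with two differences at once its value of 97 nM cannot be read as the effect of either change alone.

On the evidence available, a pyridin-2-yl in place of phenyl on the carbonyl carbon is expected to give at most a small step from compound 2 to compound 4 in this assay, probably within the scatter, with a slight lean toward a weaker inhibitor: a 1.4-fold higher number from compound 2 to compound 4 (0.15 log units; within the scatter). Compound 4 is therefore estimated at 45 nM, within a range of 15 nM to 140 nM.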

Compound 4, half-maximal inhibitory concentration: 34 nM
For compound 4 the middle estimate is 1.3-fold (0.12 log units) above the measured one; the measured number falls inside the stated range.
By their numbers in this assay, from the lowest: compounds 2 and 4 (each within the scatter of the next); then compounds 1 and 3 (each within the scatter of the next).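

In this assay, within the data shown here, pyridin-2-yl in place of phenyl on the carbonyl carbon gives a 1.1-fold higher number from compound 2 to compound 4 (0.03 log units; within the scatter), and this is the first comparison in the set that isolates a change at this position. With the butyl chain and the methoxy group held fixed, compound 2 and compound 4 cannot be told apart, so a ring nitrogen and a hydrogen-bond acceptor enter here with no change in the read-out that stands clear of the scatter. Nothing measured alongside these values accounts for this result.

On these data alone, compound 3 still differs from compound 4 in more than one place, so what pyridin-3-yl on this carbonyl carbon does with the methoxy group in place remains open, as does the separate contribution of the trifluoromethyl group. Also open, as far as these compounds go, is whether the position would tolerate groups further from phenyl and pyridin-2-yl, such as a piperidine ring, a pyridin-2-yl ring carrying a carboxylic acid, or a simple methyl group on the carbonyl carbon.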